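Oxolanyl in place of cyclobutyl on the amide carbonyl

The compounds below may be only part of what the source reports. "The series", "measured", "known", "first", "only" and "open" are said of these compounds alone.

Measured compounds in a physicochemical assay for lipophilicity, read by HPLC; a higher number here means a more lipophilic compound, a lower number a more polar compound:
- compound 1 `CCn1c(-c2cnc(C)nc2)nc2c(O[C@H]3CCN(C(=O)C4CCC4)C3)ncnc21`: 1.3
- compound 2 `CCn1c(-c2ccc(C(F)(F)F)nc2)nc2c(O[C@H]3CCN(C(=O)C4CC4)C3)ncnc21`: 2.3
- compound 3 `CCC(=O)N1CC[C@H](Nc2ncnc3c2nc(-c2cnc(C)nc2)n3CC)C1`: 0.7

Compound 1 stands second highest of the three numbers. Its nearest neighbour is compound 3, whose number lies lower by a gap beyond the scatter; compound 2 lies furthest off, higher by a gap also beyond the scatter. Among the compounds with values here, no pair among the measured compounds differs in a single place, so no measured step is available to lean on.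

Compound 4 `CCn1c(-c2cnc(C)nc2)nc2c(O[C@H]3CCN(C(=O)C4CCOC4)C3)ncnc21` is not yet measured. Relative to compound 1 the change is oxolan-3-yl in place of cyclobutyl on a carbonyl carbon. A four-membered ring of carbon only gives way to a five-membered ring with one hetero atom, at the carbonyl carbon whose other neighbour is the amide-type nitrogen in a ring.

In the absence of any measured step of this kind, the expectation for compound 4 is a downward step of a number 0.70 log units lower from compound 1 to compound 4 (beyond the scatter), beyond the scatter. Compound 4 is therefore estimated at 0.6, with a range of 0.1 to 1.1.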

Compound 4, distribution coefficient: 0.7
Compound 4: middle estimate off by 0.10 log units, on the low side, and the stated range covers the measured number.
By their numbers in this assay, from the lowest: compounds 3 and 4 (each within the scatter of the next); then compound 1; then compound 2.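

In this assay, within the data shown here, the single change at this position, oxolan-3-yl in place of cyclobutyl on a carbonyl carbon whose other neighbour is the amide-type nitrogen in a ring, gives a number 0.60 log units lower from compound 1 to compound 4 (beyond the scatter). This is the only step among the compounds shown that differs in one place, so it gives the series its first direct reading at this carbonyl. The entering group has 5 heavy atoms and 1 hydrogen-bond acceptor against 4 and 0 for cyclobutyl, but no measurement shown explains why the number moves.

Going by these compounds, it remains open whether the step carries over to a different group on the shared core, such as the trifluoromethyl-bearing ring of compound 2. Also open, on these data alone, is how an open-chain ether such as 2-methoxyethyl, or a basic amine such as piperidin-4-yl, would read at this carbonyl.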